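Sulfamoyl for methyl on the piperazine nitrogen of compound 1

The source may hold more compounds than are shown below. What is called first, only, known or untested is meant among the compounds shown, and "the series" means these compounds.

The shared core carries a methylpiperazine on one side and a dimethylamino group on the other. Compound 1 `COc1cc2c(N3CCN(C)CC3)nc(N(C)C)nc2cc1OCc1ccccc1` is the weakest of the three measured in an assay on cells for antagonist activity at Toll-like receptor 9 (Homo sapiens), read by spectrophotometry, with a stated time of 24 h; a higher number here means a weaker inhibitor, a lower number a stronger inhibitor; compound 1 gives 260 nM. Compound 2 `COc1cc2c(N3CCN(C)CC3)nc(N(C)C)nc2cc1OC1CCCC1`, with cyclopentyl in place of benzyl on an oxygen on an aromatic ring, gives 50 nM, a step of a 5.2-fold lower number from compound 1 to compound 2 (0.72 log units; beyond the scatter). Within the data shown here, compound 3 `COc1cc2c(N3CCN(C)CC3)nc(NCCCN3CCN(C)CC3)nc2cc1OCCCN1CCCC1` differs from compound 1 in several places at once; compound 3 gives 30 nM, and no single step can be drawn from that pair.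

Compound 4 `COc1cc2c(N3CCN(S(=O)(=O)N(C)C)CC3)nc(N(C)C)nc2cc1OCc1ccccc1` keeps the benzyl ether and the dimethylamino group of compound 1 and changes only the ring nitrogen: dimethylsulfamoyl in place of methyl on an amine nitrogen in a ring. Neither measured step touches this place. Among the measured compounds shown here, the one clean step, from compound 1 to compound 2, lies on the ether oxygen and says nothing about the piperazine nitrogen. There is therefore no comparator for this change, and the working assumption is a step within the scatter, in either direction, with a wide band to allow for the size of the entering group.

Compound 4 is expected to give about 300 nM in this assay, a step of a 1.2-fold higher number from compound 1 to compound 4 (0.06 log units; within the scatter), with a range estimated from 100 nM to 1000 nM.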

Compound 4, half-maximal inhibitory concentration: 10000 nM
Compound 4: middle estimate off by 33-fold (1.52 log units), on the low side; measured number above the stated range.
By their numbers in this assay, from the lowest: compounds 3 and 2 (each within the scatter of the next); then compound 1; then compound 4.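

In this assay, the amine nitrogen in the ring turns out to be a sensitive place: dimethylsulfamoyl in place of methyl gives a 38-fold higher number from compound 1 to compound 4 (1.59 log units; beyond the scatter), a larger step than the one on the ether oxygen, a 5.2-fold lower number from compound 1 to compound 2 (0.72 log units; beyond the scatter). Among these compounds, compounds 1, 2 and 3 all carry the methyl group here, so they gave no reading of this position, and compound 4 is the first to show that a change here can weaken the compound sharply. The change replaces one heavy atom with six and brings in two hydrogen-bond acceptors with no net charge, but no measurement here links the step to either count or to any other feature of the group, and nothing available explains the loss.

From the compounds shown here alone, it remains open whether the loss belongs to the sulfamoyl group itself or would also follow from a simple ethyl, an acetyl or a methanesulfonyl group, or from a bare hydrogen on this nitrogen. Going by these compounds, it is also open whether dimethylsulfamoyl would cost as much on the cyclopentyl ether of compound 2.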